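This account rests on a few compounds, and the source may have more. Where it says the series, first, only, none or still open, it means among the compounds named here.

Working notes on the series

Three compounds have a number in a functional assay on L02 cells (Homo sapiens) for inhibition, read by Griess assay, with stated times of 1 h and 24 h; a lower number here means a stronger inhibitor, a higher number a weaker inhibitor. Compound 1, `CCCc1nn(C)c2c(NC(C)C)nc(/C=C/c3nc(C)c(C)nc3C)nc12`, gives 342000 nM. Compound 2, `CCCc1nn(C)c2c(NC(C)C)nc(/C=C/c3cccnc3)nc12`, gives 574000 nM. Compound 3, `COc1cc(/C=C/c2nc(N3CCCC3)c3sccc3n2)cc(OC)c1OC`, gives 681000 nM. Within the data shown here, the one single-point step between measured compounds is a 1.7-fold higher number from compound 1 to compound 2 (0.22 log units; within the scatter), a change of the aryl group on the double bond, which leaves the shared core untouched. Compound 3 stands within the usual scatter of both other numbers: against compound 2 the gap is small, and against compound 1 it reaches only the edge of the scatter, so no order among the three can be read from these values.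

The next compound, compound 4, is `COc1cc(/C=C/c2nc(NC(C)C)c3sccc3n2)cc(OC)c1OC`. It differs from compound 3 in one place: isopropylamino in place of pyrrolidin-1-yl on an aromatic carbon.

Among the measured compounds shown here, no measured step addresses this change. What bears on it indirectly is that compound 1 and compound 2 carry isopropylamino on their cores while compound 3 carries pyrrolidin-1-yl, and all three numbers fall within the scatter of one another. For the measured compounds named here, the one measured step concerns a different position and says nothing about the amine. The expectation is therefore no step beyond the scatter.

Compound 4 is estimated at 600000 nM, with a range from 300000 nM to 1200000 nM, which means an expected step of a 1.1-fold lower number from compound 3 to compound 4 (0.05 log units; within the scatter).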

Compound 4, half-maximal inhibitory concentration: > 1000000 nM
Compound 4 gave a limit, no number (the forecaster's own chance of this, stated with the estimate: 15%); middle value at least 1.6-fold (0.22 log units) away from the limit.
By their numbers in this assay, from the lowest: compounds 1, 2 and 3 (each within the scatter of the next). At a limit, above all of these: compound 4.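

Compound 4 gives > 1000000 nM in this assay, and this is a limit of the assay, not a number. The series now has its first reading at the aromatic carbon next to the ring nitrogen, where the earlier step concerned only the aryl group on the double bond: isopropylamino in place of pyrrolidin-1-yl gives an at least 1.4-fold higher number from compound 3 to compound 4 (0.16 log units; that floor lies within the scatter). Only a floor can be read from this step, so the change is not shown to go beyond the scatter, yet no upper end is set on it either: the limit of > 1000000 nM in this assay, at which 1 of the 4 values shown sits.

The change removes a five-membered non-aromatic ring and brings in a hydrogen-bond donor in a single step, and the compounds shown do not separate these two differences. A dimethylamino group on the same aromatic carbon, with no ring and no donor, would separate them, and a piperidin-1-yl or morpholin-4-yl group would test whether the ring itself can be varied at this place.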